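The compounds below may be only part of what the source reports. "The series", "measured", "known", "first", "only" and "open" are said of these compounds alone.

Compound 1 `NNc1ncnc2c1cnn2C1O[C@H](CO)[C@@H](O)[C@H]1O` and compound 2 `CC(C)=CCNc1ncnc2c1cnn2C1O[C@H](CO)[C@@H](O)[C@H]1O` share a core and differ in the group on one nitrogen. In a functional assay on L929 cells for inhibition, with L cells (Mus musculus) as the target (a lower number here means that less compound is needed, a higher number that more compound is needed for the effect), compound 1 gives 100 uM. On these data alone, compound 2 gives > 100 uM, which is a limit of the assay and not a number, so its true position is unknown.

Compound 3 `OC[C@H]1OC(n2ncc3c(NCc4ccco4)ncnc32)[C@H](O)[C@@H]1O` keeps the core but carries furan-2-yl in place of 2-methylprop-1-en-1-yl on a saturated chain carbon bound to a nitrogen on an aromatic ring.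

Within the data shown here, the only measured step nearby is a number no lower from compound 1 to compound 2 (the limit leaves the size open), and its size stays open because of the limit of > 100 uM in this assay, at which 1 of the 2 values shown sits. It involves a different exchange and gives no size to carry over, so no shift beyond the usual scatter is expected in this assay. The expected step that the limit leaves unreadable from compound 2 to compound 3 is estimated to have no firm direction. For compound 3 the estimate is 130 uM, with an expected range of 50 uM to 350 uM.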

Compound 3, concentration for half-maximal effect: 3 uM
Beside the measured number, compound 3's estimate is 43-fold (1.64 log units) above it, and the stated range ends above it.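

The group on the nitrogen on an aromatic ring can matter strongly in this assay: a (furan-2-yl)methyl group in place of amino gives a 33-fold lower number from compound 1 to compound 3 (1.52 log units; beyond the scatter). Against 3-methylbut-2-en-1-yl, the exchange gives an at least 33-fold lower number from compound 2 to compound 3 (1.52 log units; beyond the scatter), so two groups of similar size at this place can lie far apart. The value of compound 2 is a limit of the assay and not a number, which makes the size of that step a minimum only: the limit of > 100 uM in this assay, at which 1 of the 3 values shown sits.

Whether the furan ring in particular accounts for the large step stays open, as it is the only aromatic ring at this place among the compounds shown. A benzyl or (thiophen-2-yl)methyl group on the same nitrogen would show whether the ring oxygen is needed or any aromatic ring will do.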